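The source may report more compounds than this note shows. Statements on the series, on what has been measured and on what is new or still open speak of the compounds shown alone.

Measured so far in a functional assay on SK-BR-3 cells (Homo sapiens) for cytotoxicity, read by MTT assay, with a stated time of 72 h; on this read-out higher numbers stand for an effect only at larger amounts of compound and lower numbers for an effect already at smaller amounts:
compound 1, `COc1ccc(Nc2cc(C3CCCCC3)oc(=O)c2)cc1`: 5.29 uM
compound 2, `COc1ccc(Nc2cc(-c3ccco3)oc(=O)c2)cc1`: 1.76 uM

Compound 2 has the lowest number of the two measured compounds; the nearest is compound 1, and the step from it, a 3.0-fold lower number from compound 1 to compound 2 (0.48 log units; beyond the scatter), lies beyond the scatter.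

Compound 3, `COc1ccc(Nc2cc(C3CCCC3)oc(=O)c2)cc1`, has not yet been measured in this assay. Its difference from compound 2 is cyclopentyl in place of furan-2-yl on an aromatic carbon. Among the compounds with values here, only one measured step bears on this place: a 3.0-fold lower number from compound 1 to compound 2 (0.48 log units; beyond the scatter), in which a non-aromatic carbon ring gave way to the furan and the number fell. Compound 3 puts a non-aromatic carbon ring back, so much of that step is expected to be given back, and the expected step is a 2.3-fold higher number from compound 2 to compound 3 (0.36 log units; beyond the scatter), upward, toward the number of compound 1. Compound 3 is therefore estimated at 4 uM, with a range from 1.5 uM to 10 uM.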

Compound 3, concentration for half-maximal effect: 4.73 uM
Beside the measured number, compound 3's estimate is 1.2-fold (0.07 log units) below it; the measured number falls inside the stated range.
By their numbers in this assay, from the lowest: compound 2; then compounds 3 and 1 (each within the scatter of the next).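

In this assay, the furan-2-yl group at this place, next to the ring oxygen, now stands against a second non-aromatic carbon ring, and with cyclopentyl the step is a 2.7-fold higher number from compound 2 to compound 3 (0.43 log units; beyond the scatter), although both groups carry 5 heavy atoms. Among the non-aromatic carbon rings, the step is a 1.1-fold lower number from compound 1 to compound 3 (0.05 log units; within the scatter), so cyclopentyl and cyclohexyl cannot be told apart here, and the two compounds with these rings both stand apart from compound 2. No measurement at hand explains the difference between the furan-2-yl and cyclopentyl compounds.

The compounds shown do not separate the role of the furan's ring oxygen from that of its aromatic ring. Phenyl and thiophen-2-yl at this place would address that, while an open-chain group such as n-pentyl would test whether any ring is needed.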